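A few compounds are considered here, and "the series" means these few. Any claim that something is new, unique, unknown or untested is made for them only; others in the source may bear on it.

Of the compounds shown here, three sharing one core have been measured in a functional assay on CHO cells for agonist activity at Melanocortin receptor 4 (Homo sapiens), read by cAMP accumulation; a higher number here means that more compound is needed for the effect, a lower number that less compound is needed. Compound 1 `CC(=O)N1C[C@@H](C(=O)N2CCN(c3ccc(C)cc3[C@@H](NC(=O)CCN(C)C)C(C)C)CC2)[C@H](c2ccc(Cl)cc2)C1` gives 44 nM in this assay. Compound 2 `CC(C)[C@H](NC(=O)CCN(C)C)c1cccc(F)c1N1CCN(C(=O)[C@@H]2CN(C(C)C)C[C@H]2c2ccc(Cl)cc2)CC1` gives 20 nM. Compound 3 `Cc1ccc(N2CCN(C(=O)[C@@H]3CN(C4CCOCC4)C[C@H]3c3ccc(Cl)cc3)CC2)c([C@@H](NC(=O)[C@H](C)N)C(C)C)c1` gives 5.2 nM. Among these three numbers compound 2 stands second highest; its nearest neighbour is compound 1, whose number is higher by a margin beyond the usual scatter of repeated runs, and furthest from it is compound 3, whose number is lower by a wider margin, also beyond the scatter.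

Compound 4 `CC(C)[C@H](NC(=O)CCN(C)C)c1cccc(F)c1N1CCN(C(=O)[C@@H]2CN(C(C)C)C[C@H]2c2ccc(C(F)(F)F)c(F)c2)CC1` has not yet been measured. It differs from compound 2 in one place: 3-fluoro-4-(trifluoromethyl)phenyl in place of 4-chlorophenyl on a saturated ring carbon. In words, 3-fluoro-4-(trifluoromethyl)phenyl takes the place of 4-chlorophenyl on a saturated ring carbon of a five-membered non-aromatic ring with one nitrogen. Going by the values given here, no measured pair among the three compounds shows this exchange, so its effect in this assay cannot be read from them; compounds 1, 2 and 3 differ from one another in other parts of the molecule. The exchange keeps one six-membered aromatic ring of carbon only in that position, and the expected step is no change at the digits printed from compound 2 to compound 4 (within the scatter), no larger than the usual scatter, in either direction. Compound 4 is therefore estimated at 20 nM in this assay, with a range from 6 nM to 70 nM.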

Compound 4, half-maximal effective concentration: 340 nM
Estimate against measurement, compound 4: 17-fold (1.23 log units) below; measured number outside the range, above it.
By their numbers in this assay, from the lowest: compound 3; then compound 2; then compound 1; then compound 4.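

In this assay, exchanging 4-chlorophenyl for 3-fluoro-4-(trifluoromethyl)phenyl on the saturated ring carbon gives a 17-fold higher number from compound 2 to compound 4 (1.23 log units; beyond the scatter), so this position responds strongly to what the aromatic ring carries, even though one six-membered aromatic ring of carbon stays in place. Going by these compounds alone, compounds 1, 2 and 3 all hold 4-chlorophenyl here, so only this pair shows that a change confined to that ring's substituents, taking the group from 7 to 11 heavy atoms and adding no hydrogen-bond donors or acceptors, can shift the number this far. Nothing available here accounts for the size of this step.

The exchange alters the ring in two ways at once, with trifluoromethyl taking the place of chlorine and a fluorine being added, and a 4-(trifluoromethyl)phenyl or 3-fluoro-4-chlorophenyl group would be needed to tell these two parts apart. Also open, on these data alone, is whether the step would carry over to the other groups seen in compounds 1 and 3, and how a saturated cyclohexyl ring would compare with these aromatic rings at this position.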